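This account rests on a few compounds, and the source may have more. Where it says the series, first, only, none or still open, it means among the compounds named here.

Measured compounds:
compound 1 `CC(=O)OC[C@H]1O[C@@H](n2cc(CN3C(=O)/C(=C\c4ccc5ccccc5c4)c4ccccc43)nn2)[C@H](OC(C)=O)[C@@H](OC(C)=O)[C@@H]1OC(C)=O` gives > 100000 nM
compound 2 `CCC/C=C1/C(=O)N(Cc2cn([C@@H]3O[C@H](COC(C)=O)[C@@H](OC(C)=O)[C@H](OC(C)=O)[C@H]3OC(C)=O)nn2)c2ccccc21` gives 19700 nM

In a functional assay on DU-145 cells (Homo sapiens) for cytotoxicity, read by sulforhodamine B assay, with a stated time of 48 h (on this read-out lower numbers stand for stronger inhibition and higher numbers for weaker inhibition), compound 1 gives > 100000 nM, which is a limit of the assay rather than a number (the limit of > 100000 nM in this assay, at which 1 of the 2 values shown sits). In this assay, among the measured compounds shown here, compound 2 gives 19700 nM, the only numerical value in this set. Compound 3 `CCC/C=C1\C(=O)N(Cc2cn([C@@H]3O[C@H](COC(C)=O)[C@@H](OC(C)=O)[C@H](OC(C)=O)[C@H]3OC(C)=O)nn2)c2ccccc21` differs from compound 2 in that (the two compounds have the same atoms and bonds and differ only in configuration as drawn: 1 of 6 stereo elements differ; a double bond is drawn E in compound 2 and Z in compound 3). For the measured compounds named here, no step between measured compounds is available for this kind of change, so the expected step from compound 2 to compound 3 is a 1.1-fold higher number from compound 2 to compound 3 (0.05 log units; within the scatter), not beyond the usual scatter. Compound 3 is therefore estimated at 22000 nM, with a range from 6000 nM to 90000 nM.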

Compound 3, half-maximal inhibitory concentration: 26600 nM
Compound 3: the middle estimate sits 1.2-fold (0.08 log units) below what was measured; measured number inside the range.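

In this assay, drawing the double bond Z rather than E gives a 1.4-fold higher number from compound 2 to compound 3 (0.13 log units; within the scatter), so at this double bond the configuration as drawn leaves the read-out within the scatter. Propyl in place of naphthalen-2-yl on the double-bonded chain carbon gives an at least 3.7-fold lower number from compound 1 to compound 3 (0.57 log units; beyond the scatter), the first step in one place that bears on this substituent. The value of compound 1 is a limit and not a number: the limit of > 100000 nM in this assay, at which 1 of the 3 values shown sits.

Going by these compounds, it remains open how a longer chain, an amine or a carboxylic acid at this carbon would read. On these data alone, it also remains open whether the two double-bond configurations would stay within the scatter with naphthalen-2-yl in place of propyl.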